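Compound 1 to compound 4: changing the group on sulfur

This account rests on a few compounds, and the source may have more. Where it says the series, first, only, none or still open, it means among the compounds named here.

In a functional assay on HeLa cells (Homo sapiens) for inhibition, read by CCK-8 assay, with a stated time of 72 h, tested at 8 uM (a higher number here means more inhibition of growth at the concentration tested, a lower number less inhibition of growth), compound 1 `Cc1cc(C)cc(SCc2ccc(/C=C/C(=O)Nc3ccccc3N)cc2)c1` gives 3.39%, the lowest of the three numbers. Compound 2 `CCc1ccc(SCc2ccc(C(=O)Nc3ccccc3N)cc2)cc1` gives 71%. Compound 3 `Nc1ccccc1NC(=O)c1ccc(CSc2cccc(F)c2)cc1` gives 78.4%. The numbers of both these compounds lie beyond the scatter from that of compound 1. Compound 4 `Nc1ccccc1NC(=O)/C=C/c1ccc(CSc2ccc(C(F)(F)F)cn2)cc1` keeps the core of compound 1 and changes one group on the sulfur: 5-(trifluoromethyl)pyridin-2-yl in place of 3,5-dimethylphenyl on a sulfur. For the measured compounds named here, the only measured step with a change at that sulfur is a number 7.4 percentage points higher from compound 2 to compound 3 (within the scatter). It was measured on a different core from that of compound 1, so it is only a loose guide. The expected step is a number 6.6 percentage points higher from compound 1 to compound 4 (within the scatter), so no change beyond the scatter is expected. For compound 4 the estimated value is 10%, with an expected range of 1% to 35%.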

Compound 4, percent growth inhibition at one concentration: 6.82%
Compound 4: the middle estimate sits 3.2 percentage points above what was measured, within the range that was stated.
By their numbers in this assay, from the lowest: compounds 1 and 4 (each within the scatter of the next); then compounds 2 and 3 (each within the scatter of the next).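

In this assay, the first change measured at the sulfur on the core of compound 1, 5-(trifluoromethyl)pyridin-2-yl in place of 3,5-dimethylphenyl, gives a number 3.4 percentage points higher from compound 1 to compound 4 (within the scatter). This core therefore accepts a ring with 1 hetero atom and a hydrogen-bond acceptor at this place with no readable shift in the number. No measurement shown here offers an explanation for this result.

Going by these compounds, it remains open whether a longer alkyl chain, or a phenyl ring carrying an amine or a carboxylic acid, on the sulfur would move the number on this core beyond the scatter.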